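Nitro in Place of Hydroxy on a Shared Core

The source may hold more compounds than are shown below. What is called first, only, known or untested is meant among the compounds shown, and "the series" means these compounds.

Compound 1, `Cc1ccc(Nc2cncc(N3CC4CC(C3)N4)c2)cc1`, gives 0.148 nM in an assay on cell membranes for displacement of a labelled ligand from Neuronal acetylcholine receptor; alpha4/beta2 (Rattus norvegicus); on this read-out lower numbers stand for stronger inhibition and higher numbers for weaker inhibition.
Compound 2, `Clc1ccc(Nc2cncc(N3CC4CC(C3)N4)c2)cc1`, gives 0.118 nM in this assay.
Compound 3, `Oc1ccc(Nc2cncc(N3CC4CC(C3)N4)c2)cc1`, gives 0.342 nM in this assay.

Among these three, compound 3 stands with the highest number. The steps that separate it from the other two are a 2.3-fold higher number from compound 1 to compound 3 (0.36 log units; beyond the scatter) and a 2.9-fold higher number from compound 2 to compound 3 (0.46 log units; beyond the scatter), both modest and both beyond the scatter. Between the other two compounds the step is a 1.3-fold lower number from compound 1 to compound 2 (0.10 log units; within the scatter), so methyl and chloro are not told apart on this read-out.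

Compound 4, `O=[N+]([O-])c1ccc(Nc2cncc(N3CC4CC(C3)N4)c2)cc1`, differs from compound 3 in one place: nitro in place of hydroxy on an aromatic carbon. For the measured compounds named here, no measured step swaps a hydroxy for a nitro, so the two steps that end at compound 3 are the only ones that bear on it. Read in reverse, each says that exchanging the hydroxy for another group at this carbon gave a modestly lower number. A group with two hydrogen-bond acceptors and no donor has not been tried, so the direction is taken from those two steps with caution, and the step for compound 4 is expected to be a 1.7-fold lower number from compound 3 to compound 4 (0.23 log units; within the scatter). Compound 4 is therefore estimated at 0.2 nM, with a range from 0.07 nM to 0.6 nM.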

Compound 4, inhibition constant: 0.0225 nM
The estimate for compound 4 lay 8.9-fold (0.95 log units) above the measured number, and the stated range ends above it.
By their numbers in this assay, from the lowest: compound 4; then compounds 2 and 1 (each within the scatter of the next); then compound 3.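

On the aromatic carbon para to a large group, the earlier exchanges among hydroxy, methyl and chloro moved the number in this assay by modest steps at most, while nitro brings a 15-fold lower number from compound 3 to compound 4 (1.18 log units; beyond the scatter) and so gives this position its first large step. Nitro also stands apart from chloro and methyl, which were not told apart, through a 5.2-fold lower number from compound 2 to compound 4 (0.72 log units; beyond the scatter) and through a 6.6-fold lower number from compound 1 to compound 4 (0.82 log units; beyond the scatter) as well, which leaves compound 4 alone at the low end of the four numbers. Nothing available here accounts for this result.

The compounds shown cannot tell whether the low number belongs to nitro alone or would also appear with a nitrile, a trifluoromethyl or a carboxylic acid on the same carbon. Nor do they say whether an amine or a methoxy there would stay close to hydroxy, or what nitro would do on another carbon of the six-membered aromatic ring.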